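This account rests on a few compounds, and the source may have more. Where it says the series, first, only, none or still open, it means among the compounds named here.

Three compounds have been measured in a functional assay on HeLa cells (Homo sapiens) for cytotoxicity, read by WST assay, with a stated time of 48 h; on this read-out higher numbers stand for weaker inhibition and lower numbers for stronger inhibition:

compound 1, `COc1ccc([C@@H]2OC[C@H]([C@@H](O)c3ccc(OC)c(OC)c3)C[C@H]2C/C=C/c2ccc(OC)c(OC)c2)cc1`, gives 29200 nM
compound 2, `Oc1ccccc1/C=C/C[C@H]1C[C@@H]([C@@H](O)c2ccccc2)CO[C@@H]1c1ccccc1`, gives 21800 nM
compound 3, `COc1ccc(/C=C/C[C@H]2C[C@@H]([C@@H](O)c3ccccc3)CO[C@@H]2c2ccc(OC)c(OC)c2)cc1OC`, gives 15500 nM

All three numbers lie close together. Compound 2 stands second highest of the three, but its gap to compound 1 and its gap to compound 3 are both within the usual scatter of repeated measurements, so the three compounds cannot be told apart on these numbers; each of them is a weak inhibitor in this assay.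

Compound 4, `O[C@@H](c1ccccc1)[C@H]1CO[C@H](c2ccccc2)[C@@H](C/C=C/c2ccccc2F)C1`, has not yet been measured. It differs from compound 2 in one place: fluoro in place of hydroxy on an aromatic carbon. Among the measured compounds shown here, no pair among the measured compounds shows what a change of this kind does, so there is no measured step to lean on. The three measured compounds, which differ from each other in several places at once, all sit in the same weak range, and a single small swap on one aromatic ring gives no reason to expect a departure from that range. The step from compound 2 to compound 4 is therefore expected to be small, most likely none beyond the scatter, as a 1.0-fold higher number from compound 2 to compound 4 (0.00 log units; within the scatter).

Compound 4 is thus estimated at 22000 nM in this assay, with a plausible range from 8000 nM to 60000 nM.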

Compound 4, half-maximal inhibitory concentration: 9730 nM
For compound 4 the middle estimate is 2.3-fold (0.35 log units) above the measured one, and the stated range covers the measured number.
By their numbers in this assay, from the lowest: compounds 4, 3, 2 and 1 (each within the scatter of the next, the first and the last beyond it).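

In this assay, among the compounds shown here, putting fluoro in place of hydroxy on an aromatic carbon ortho to a large group gives a 2.2-fold lower number from compound 2 to compound 4 (0.35 log units; beyond the scatter), the first change in a single place that can be read. The step is modest but beyond the scatter, so this position on the ring does respond to what sits there, and the hydroxy group, with its hydrogen-bond donor and acceptor, is not needed to keep the activity seen in compound 2. Nothing available explains why the number falls with this swap.

From the compounds shown here alone, it remains open whether the step comes from gaining fluoro or from losing hydroxy, and a plain hydrogen, a chloro or an amino group at this same place would help to separate the two. Going by these compounds, it is also open whether the same swap would give a similar step on a compound with methoxy groups on its rings, such as compound 1 or compound 3.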